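Azido Added to the Chloropyridine Arm of Compound 2

The compounds below may be only part of what the source reports. "The series", "measured", "known", "first", "only" and "open" are said of these compounds alone.

Measured so far:
compound 1 `[N-]=[N+]=Nc1cncc(Cn2ccsc2=N)c1`: 8.3 nM
compound 2 `N=c1sccn1Cc1ccc(Cl)nc1`: 0.39 nM

Both numbers come from an assay on M10 cells (Gallus gallus) for binding affinity to Neuronal acetylcholine receptor; alpha4/beta2 (Homo sapiens); a lower number here means a stronger inhibitor, a higher number a weaker inhibitor. Compound 2 has the lower of the two numbers, and compound 1 lies above it by a gap that is beyond the scatter of repeated measurements, so compound 2 is the stronger binder of the pair.

The next compound, compound 3 `[N-]=[N+]=Nc1cc(Cn2ccsc2=N)cnc1Cl`, has not been measured. It differs from compound 2 in one place: azido in place of hydrogen on an aromatic carbon. For the measured compounds named here, no measured pair differs in exactly this way, so the size of this step cannot be read from the numbers at hand. Compound 1 also carries an azido group, but it lacks the chloro group of compound 2 and differs from compound 3 in more than one place, so its higher number cannot be attributed to the azido group alone.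

The expected step from compound 2 to compound 3 is a modest rise, a 3.1-fold higher number from compound 2 to compound 3 (0.49 log units; beyond the scatter), which may still fall within the scatter. For compound 3 the estimated value in this assay is 1.2 nM, with a range from 0.3 nM to 6 nM.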

Compound 3, inhibition constant: 0.47 nM
The estimate for compound 3 lay 2.6-fold (0.41 log units) above the measured number; measured number inside the range.
By their numbers in this assay, from the lowest: compounds 2 and 3 (each within the scatter of the next); then compound 1.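

In this assay, azido in place of hydrogen on this aromatic carbon, ortho to a chloro group and two atoms from the ring nitrogen, gives a step within the scatter, a 1.2-fold higher number from compound 2 to compound 3 (0.08 log units; within the scatter), so this position of compound 2 can carry azido, with its 3 heavy atoms, and keep its very low number. The second step, an 18-fold lower number from compound 1 to compound 3 (1.25 log units; beyond the scatter), is large and beyond the scatter: with azido present on both sides of the comparison, the chloro group that compound 3 carries and compound 1 lacks goes with a far lower number, which settles what the earlier pair could not separate, and ties the higher number of compound 1 to the missing chloro group rather than to azido. Nothing measured here explains either step.

Azido is the only group shown at this position, so it remains open whether an amine, a methoxy group or a longer chain would fit there equally well. On these data alone, it is also open whether a bromo group could stand in for the chloro group, and whether azido would make as small a difference on a core without chloro.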